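A few compounds are considered here, and "the series" means these few. Any claim that something is new, unique, unknown or untested is made for them only; others in the source may bear on it.

Measured compounds and their inhibition numbers:

compound 1 `Cc1ccc(-n2c(-c3cc(-c4ccc(F)cc4F)ccc3O)n[nH]c2=S)cc1` — 51.6%
compound 2 `Oc1ccc(-c2ccc(F)cc2F)cc1-c1nnc(NC2CCCCC2)s1` — 41.4%
compound 3 `CCn1c(-c2cc(-c3ccc(F)cc3F)ccc2O)n[nH]c1=S` — 46.2%

In a functional assay on the whole organism (strain BALB/c) for inhibition, with Mus musculus as the target, read by paw edema, with a stated time of 4 h, at a dose of 50 mg/kg by the oral route (on this read-out lower numbers stand for less inhibition and higher numbers for more inhibition at the one dose given (going by the name of the read-out)), compound 3 gives 46.2%. It sits in the middle of the three numbers, and neither of the other two is separated from it beyond the usual scatter: compound 2 gives 41.4% and compound 1 gives 51.6%. Within the data shown here, the one step within this set that changes only the substituent on the aromatic nitrogen, a number 5.4 percentage points lower from compound 1 to compound 3 (within the scatter), is itself within the scatter.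

Compound 4 `C=CCn1c(-c2cc(-c3ccc(F)cc3F)ccc2O)n[nH]c1=S` has not been measured. It differs from compound 3 by vinyl in place of methyl on a saturated chain carbon bound to an aromatic nitrogen. The change is at the same place as the measured step, and that step, with a far larger exchange, moved the inhibition by an amount inside the scatter. Nothing in the data therefore points to a shift of the read-out beyond the scatter here, and the expected step is a number 0.2 percentage points lower from compound 3 to compound 4 (within the scatter), essentially none. Compound 4 is accordingly expected to give 46%, with a range from 34% to 58%.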

Compound 4, a percentage reported as inhibition, in the whole organism at one dose (the size of the read-out at that dose, not a potency): 73%
Estimate against measurement, compound 4: 27 percentage points below, and the stated range ends below it.
By their numbers in this assay, from the lowest: compounds 2, 3 and 1 (each within the scatter of the next, the first and the last beyond it); then compound 4.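

On the aromatic nitrogen of the shared core in this assay, a small change moves the read-out more than the earlier exchange of 4-methylphenyl for ethyl, which stayed within the scatter: vinyl in place of methyl on the saturated chain carbon, which reads as ethyl to allyl, gives a number 26.8 percentage points higher from compound 3 to compound 4 (beyond the scatter) in this series. Allyl in place of 4-methylphenyl on the same nitrogen likewise gives a number 21.4 percentage points higher from compound 1 to compound 4 (beyond the scatter) and so places compound 4 clear of both other compounds with a substituent at this position. Nothing shown here explains this gain.

On these data alone, whether the gain depends on the double bond remains open, and a propyl chain would test this directly. A propargyl group, a longer chain such as butyl, or a chain carrying an amine could show how far the gain extends.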